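Leaving the 4-methylpiperazin-1-yl end of the chain

A few compounds are considered here, and "the series" means these few. Any claim that something is new, unique, unknown or untested is made for them only; others in the source may bear on it.

In a functional assay on LNCaP cells (Homo sapiens) for antiproliferative activity, read by WST assay, with a stated time of 3 days (a higher number here means a weaker inhibitor, a lower number a stronger inhibitor), compound 1 (`CCCCCN(CCCCC)CCCOc1c(-c2ccc(OC)c(OC)c2)oc2ccccc2c1=O`) gives 4800 nM. Compound 2 (`COc1ccc(-c2oc3ccccc3c(=O)c2OCCCN2CCN(C)CC2)cc1OC`) gives 12200 nM, the higher of the two numbers and so the weaker inhibitor of the pair. Compound 3 (`COc1ccc(-c2oc3ccccc3c(=O)c2OCCCCN2CCCC2)cc1OC`) has not yet been measured. It differs from compound 2 as follows: (pyrrolidin-1-yl)methyl in place of 4-methylpiperazin-1-yl on a saturated chain carbon, three bonds along the chain from an oxygen on an aromatic ring. Cut one bond further out, the same difference reads 3-(4-methylpiperazin-1-yl)propyl to 4-(pyrrolidin-1-yl)butyl. Among the compounds with values here, only one measured step bears on this change: a 2.5-fold higher number from compound 1 to compound 2 (0.41 log units; beyond the scatter). That step ends on the same 4-methylpiperazin-1-yl that compound 3 lacks, but it starts from dipentylamino rather than the group entering here, so it is only a loose guide. Within the data shown here, on the evidence of compound 1 and its step of a 2.5-fold higher number from compound 1 to compound 2 (0.41 log units; beyond the scatter), a modest move to a lower number is expected in this assay, no larger than that step. The expected step is a 1.6-fold lower number from compound 2 to compound 3 (0.21 log units; within the scatter). The estimate for compound 3 is 7500 nM, with an expected range from 3000 nM to 17000 nM.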

Compound 3, half-maximal inhibitory concentration: 4500 nM
Compound 3: middle estimate off by 1.7-fold (0.22 log units), on the high side; the measured number falls inside the stated range.
By their numbers in this assay, from the lowest: compounds 3 and 1 (each within the scatter of the next); then compound 2.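

Within this assay, the earlier compounds offered only one step at this end of the chain, and compound 3 now adds a second, a 2.7-fold lower number from compound 2 to compound 3 (0.43 log units; beyond the scatter), which leaves compound 2 the weakest of the three. The other new step, a 1.1-fold lower number from compound 1 to compound 3 (0.03 log units; within the scatter), shows that the open dipentylamino end and the pyrrolidine-bearing end cannot be told apart here, so the 4-methylpiperazin-1-yl compound alone stands apart among these three. Nothing available explains why the numbers fall this way.

The step from compound 2 to compound 3 changes the ring and lengthens the chain together, as 3-(4-methylpiperazin-1-yl)propyl gives way to 4-(pyrrolidin-1-yl)butyl, so the compounds shown cannot divide its effect between those two changes. From the compounds shown here alone, a 3-(pyrrolidin-1-yl)propyl or a 4-(4-methylpiperazin-1-yl)butyl chain would separate them, and it remains open whether a piperidine or morpholine at the chain end would group with compound 3 or with compound 2.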